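Substituent variation on the aromatic nitrogen of the shared core: cycloheptyl to isopropyl

A few compounds are considered here, and "the series" means these few. Any claim that something is new, unique, unknown or untested is made for them only; others in the source may bear on it.

Measured compounds:
compound 1 `CC(C)c1onc(-c2c(Cl)cccc2Cl)c1COc1ccc(-c2nc3ccc(C(=O)O)cc3n2-c2ccc(F)cc2)cc1` — 2410 nM
compound 2 `CC(C)c1onc(-c2c(Cl)cccc2Cl)c1COc1ccc(-c2nc3ccc(C(=O)O)cc3n2CC2CC2)cc1` — 2650 nM
compound 3 `CC(C)c1onc(-c2c(Cl)cccc2Cl)c1COc1ccc(-c2nc3ccc(C(=O)O)cc3n2C2CCCCCC2)cc1` — 921 nM

In an assay on HEK-293T cells for antagonist activity at vitamin D3 receptor (Homo sapiens), read by a luciferase reporter, with a stated time of 24 h (on this read-out higher numbers stand for weaker inhibition and lower numbers for stronger inhibition), compound 3 gives the lowest number of the three; the steps to it, a 2.6-fold lower number from compound 1 to compound 3 (0.42 log units; beyond the scatter) and a 2.9-fold lower number from compound 2 to compound 3 (0.46 log units; beyond the scatter), both lie beyond the scatter, whereas a 1.1-fold higher number from compound 1 to compound 2 (0.04 log units; within the scatter) does not. Compound 4 `CC(C)c1onc(-c2c(Cl)cccc2Cl)c1COc1ccc(-c2nc3ccc(C(=O)O)cc3n2C(C)C)cc1` differs from compound 3 only in isopropyl in place of cycloheptyl on an aromatic nitrogen. The relevant precedent is the step from the smaller cyclopropylmethyl to cycloheptyl, a 2.9-fold lower number from compound 2 to compound 3 (0.46 log units; beyond the scatter), which lowered the number modestly. Isopropyl returns to a small group with three carbon atoms and no ring, so a modest rise in this assay is expected, roughly reversing that step, a 2.5-fold higher number from compound 3 to compound 4 (0.40 log units; beyond the scatter). Compound 4 is thus estimated at 2300 nM, within 1000 nM to 5000 nM.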

Compound 4, half-maximal inhibitory concentration: 3550 nM
Beside the measured number, compound 4's estimate is 1.5-fold (0.19 log units) below it; low and high end bracket the measured number.
By their numbers in this assay, from the lowest: compound 3; then compounds 1, 2 and 4 (each within the scatter of the next).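

In this assay, isopropyl in place of cycloheptyl gives a 3.9-fold higher number from compound 3 to compound 4 (0.59 log units; beyond the scatter), so the lower number of compound 3 does not carry over to this smaller group. Against the other two substituents, isopropyl gives a 1.3-fold higher number from compound 2 to compound 4 (0.13 log units; within the scatter) and a 1.5-fold higher number from compound 1 to compound 4 (0.17 log units; within the scatter), both within the scatter, so among the four compounds only cycloheptyl stands apart at this position. Nothing at hand accounts for this gap.

Open, going by these compounds, is whether cyclopentyl, cyclohexyl or a longer chain such as n-heptyl would match cycloheptyl. Also open, on these data alone, is whether an amine on the cycloheptyl ring would preserve its number.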